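Trimming the Carbamoyl Group of Compound 2

This account rests on a few compounds, and the source may have more. Where it says the series, first, only, none or still open, it means among the compounds named here.

Compound 1 `NC(=O)[C@H](CO)Nc1cc(=O)oc2cc(OCc3cccc(Cl)c3)ccc12`: 2400 nM
Compound 2 `NC(=O)Cc1cc(=O)oc2cc(OCc3cccc(Cl)c3)ccc12`: 30 nM
Compound 3 `NC(=O)Cc1cc(=O)oc2cc(OCc3cccc(F)c3)ccc12`: 50 nM

In an assay for inhibition of Amine oxidase [flavin-containing] B (Rattus norvegicus) (a higher number here means a weaker inhibitor, a lower number a stronger inhibitor), compound 2 gives the lowest of the three numbers; the step of a 1.7-fold higher number from compound 2 to compound 3 (0.22 log units; within the scatter) lies within the scatter, while the step of an 80-fold lower number from compound 1 to compound 2 (1.90 log units; beyond the scatter) is large. Compound 4 `NCc1cc(=O)oc2cc(OCc3cccc(Cl)c3)ccc12` differs from compound 2 by amino in place of carbamoyl on a saturated chain carbon bound to an aromatic carbon. Neither measured step bears directly on this change: the step from compound 1 to compound 2 reshapes the whole side chain, and the step from compound 2 to compound 3 touches only the halogen. Without a comparable step, the estimate for compound 4 rests on compound 2 alone, with a modest loss expected: a 5.0-fold higher number from compound 2 to compound 4 (0.70 log units; beyond the scatter). Compound 4 is therefore expected at 150 nM, in the range 30 nM to 800 nM.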

Compound 4, half-maximal inhibitory concentration: 15 nM
Compound 4: the middle estimate sits 10-fold (1.00 log units) above what was measured, and the stated range ends above it.
By their numbers in this assay, from the lowest: compounds 4, 2 and 3 (each within the scatter of the next, the first and the last beyond it); then compound 1.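

In this assay, amino can take the place of carbamoyl on this saturated chain carbon, with one heavy atom standing where there were three, and the result stays within the scatter: a 2.0-fold lower number from compound 2 to compound 4 (0.30 log units; within the scatter). The carbamoyl group is therefore not needed here for a low number, and the aminomethyl side chain also keeps a wide margin over the side chain of compound 1: a 160-fold lower number from compound 1 to compound 4 (2.20 log units; beyond the scatter). No measurement shown explains why the two groups can be exchanged.

On these data alone, whether a carboxylic acid, a dimethylamino group or a longer chain ending in an amine would serve in this place remains open. The compounds shown also leave open whether aminomethyl would give a similar result with the fluoro group of compound 3.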